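A few compounds are considered here, and "the series" means these few. Any claim that something is new, unique, unknown or untested is made for them only; others in the source may bear on it.

Measured so far in an assay on isolated protein for inhibition of MAP kinase-activated protein kinase 2 (Homo sapiens), read by mobility shift assay, tested at 30 uM; on this read-out higher numbers stand for more inhibition at the one concentration tested (going by the name of the read-out) and lower numbers for less inhibition:

- compound 1, `CC(=O)Nc1nn(C)c2cc(-c3ccc(N4CCN(C)CC4)cc3)[nH]c(=O)c12`: 5%
- compound 2, `COCCNc1nc(-c2ccccc2)cc2c1c(N)nn2C`: 2%
- compound 3, `Cc1cc2nn(-c3ccccc3)c(N)c2c(=O)[nH]1`: -4%

All three numbers in this assay sit close to zero, and the gaps between them lie within the usual scatter of repeated measurements. Compound 3 shows the lowest of the three numbers, but since its gap to compound 2 and its gap to compound 1 are both within the scatter, no ranking among the three can be read from them. Among the compounds with values here, none of the measured pairs differs in a single place, so no step between measured compounds is available for the series.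

Compound 4, `COc1ccccc1-c1cc2nn(-c3ccccc3)c(N)c2c(=O)[nH]1`, is not yet measured. It differs from compound 3 in one place:

2-methoxyphenyl in place of methyl on an aromatic carbon

Within the data shown here, with no measured step to lean on, and with every number so far near the floor of this assay, the expectation for compound 4 rests only on where the series sits. The step from compound 3 to compound 4 is estimated as a number 9 percentage points higher from compound 3 to compound 4 (within the scatter), which would not exceed the usual scatter. Compound 4 is therefore expected to give about 5% in this assay, with a likely range from -8% to 22%.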

Compound 4, a percentage reported as inhibition, at one concentration (the size of the read-out at that concentration, not a potency): -1%
Estimate against measurement, compound 4: 6 percentage points above; low and high end bracket the measured number.
By their numbers in this assay, from the lowest: compounds 3, 4, 2 and 1 (each within the scatter of the next).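

In this assay, putting 2-methoxyphenyl in place of methyl on the aromatic carbon next to the ring nitrogen gives a number 3 percentage points higher from compound 3 to compound 4 (within the scatter). The change replaces 1 heavy atom with 8 heavy atoms and adds a six-membered aromatic ring and a hydrogen-bond acceptor, yet the two numbers cannot be told apart. Within the data shown here, this is the first step between compounds that differ in one place, and it gives no sign that this aryl group at this position brings inhibition at the one concentration tested. No evidence is at hand that bears on this result.

From the compounds shown here alone, one step with a single aryl group cannot show how this position behaves in general, so it remains open whether an amine, a carboxylic acid or a longer alkyl chain on this carbon would move the number beyond the scatter. Also open, going by these compounds, is whether a plain phenyl, or a phenyl carrying a piperazine ring, would read any differently from 2-methoxyphenyl on the core of compound 4.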